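The source may report more compounds than this note shows. Statements on the series, on what has been measured and on what is new or still open speak of the compounds shown alone.

Working notes on the series. Two compounds have numbers in a functional assay on BXPC-3 cells (Homo sapiens) for inhibition, read by MTT assay, with a stated time of 72 h; a higher number here means a weaker inhibitor of growth, a lower number a stronger inhibitor of growth. Compound 1 `COc1ccc(CNCCCNS(=O)(=O)c2cc(C(F)(F)F)cc(C(F)(F)F)c2)cc1OC` gives 13000 nM in this assay. Compound 2 `O=S(=O)(NCCCNCc1ccc(Br)cc1)c1cc(C(F)(F)F)cc(C(F)(F)F)c1` gives 1500 nM in this assay, the lowest of the two numbers shown, and the only step measured so far, an 8.7-fold lower number from compound 1 to compound 2 (0.94 log units; beyond the scatter), separates them. Compound 3 `COc1ccc(CNCCCNS(=O)(=O)c2cc(C(F)(F)F)cc(C(F)(F)F)c2)cc1` has not been measured in this assay. The change from compound 2 to compound 3 is methoxy in place of bromo on an aromatic carbon, so compound 3 carries a 4-methoxyphenyl on the benzylic position where compound 1 carries 3,4-dimethoxyphenyl and compound 2 carries 4-bromophenyl. Within the data shown here, the one measured step that bears on this is an 8.7-fold lower number from compound 1 to compound 2 (0.94 log units; beyond the scatter), a modest drop when two methoxy groups were exchanged for bromo. Exchanging bromo for a single methoxy is expected to move the number back upward, but not necessarily all the way to compound 1, so the expected step is a 3.3-fold higher number from compound 2 to compound 3 (0.52 log units; beyond the scatter). For compound 3 the estimate in this assay is 5000 nM, within 2000 nM to 13000 nM.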

Compound 3, concentration for 50% growth inhibition: 1300 nM
For compound 3 the middle estimate is 3.8-fold (0.59 log units) above the measured one; the measured number lies below the stated range.
By their numbers in this assay, from the lowest: compounds 3 and 2 (each within the scatter of the next); then compound 1.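

In this assay, methoxy in place of bromo on the aromatic carbon gives a 1.2-fold lower number from compound 2 to compound 3 (0.06 log units; within the scatter), so a single methoxy and bromo cannot be told apart at this position, and the poorer number of compound 1 cannot be read as a general penalty for methoxy. The larger move comes with hydrogen in place of the additional methoxy, a 10-fold lower number from compound 1 to compound 3 (1.00 log units; beyond the scatter), which ties the gap in this pair to that second methoxy of the 3,4-dimethoxyphenyl group. No measurement bears on the cause of either step.

As far as these compounds go, whether a plain benzyl, a 4-chlorobenzyl or a 4-hydroxybenzyl group would give a number in the same range as compound 2 and compound 3 remains open. Also open, from the compounds shown here alone, is whether this tolerance at the aromatic carbon would persist with a longer chain in the shared core.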